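Swapping Bromo for Methyl on Compound 2

The compounds below may be only part of what the source reports. "The series", "measured", "known", "first", "only" and "open" are said of these compounds alone.

Among the measured compounds shown here, in a functional assay on HepG2 cells (Homo sapiens) for cytotoxicity, read by sulforhodamine B assay, with a stated time of 24 h (a lower number here means a stronger inhibitor, a higher number a weaker inhibitor), compound 1 (`N#CCC(=O)N/N=C1\C(=O)Nc2ccc(S(=O)(=O)N3CCOCC3)cc21`) gives 7530 nM and compound 2 (`O=C1Nc2ccc(S(=O)(=O)N3CCOCC3)cc2/C1=N/c1ccc(Br)cc1`) gives 11900 nM, so compound 2 stands within the scatter of the only other measured number. Compound 3 (`Cc1ccc(/N=C2\C(=O)Nc3ccc(S(=O)(=O)N4CCOCC4)cc32)cc1`) has not yet been measured. It carries methyl in place of bromo on an aromatic carbon, para to a large group: methyl in place of bromo on an aromatic carbon. For the measured compounds named here, the one measured step that bears on this, a 1.6-fold higher number from compound 1 to compound 2 (0.20 log units; within the scatter), came with 4-bromophenyl in place of ((cyanomethyl)carbonyl)amino on a double-bonded nitrogen. Going by the values given here, no measured pair shows the bromo-to-methyl swap itself, so this evidence is thin, but no step beyond the scatter is expected in this assay. For compound 3 the estimated value is 11000 nM, with an expected range from 5000 nM to 25000 nM. That estimate means an expected 1.1-fold lower number from compound 2 to compound 3 (0.03 log units; within the scatter).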

Compound 3, half-maximal inhibitory concentration: 12800 nM
Compound 3: middle estimate off by 1.2-fold (0.07 log units), on the low side; the range from low to high includes it.
By their numbers in this assay, from the lowest: compounds 1, 2 and 3 (each within the scatter of the next).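

In this assay, among the compounds shown here, methyl in place of bromo on the aromatic carbon gives a 1.1-fold higher number from compound 2 to compound 3 (0.03 log units; within the scatter), so this spot, para to a large group, takes either of these two groups, each of one heavy atom, with no step that stands out from the scatter. The larger exchange, 4-methylphenyl in place of ((cyanomethyl)carbonyl)amino on the double-bonded nitrogen, gives a 1.7-fold higher number from compound 1 to compound 3 (0.23 log units; within the scatter), so the three compounds shown cannot be told apart in this test. No measurement at hand accounts for this flat picture.

The compounds shown leave open whether a different kind of group on that aromatic carbon, such as an amine or a carboxylic acid, would produce a step beyond the scatter. Going by these compounds, a longer chain at the same spot remains equally open.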